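A few compounds are considered here, and "the series" means these few. Any claim that something is new, unique, unknown or untested is made for them only; others in the source may bear on it.

Measured so far:
- compound 1, `O=C(CCCCCCc1ccccc1)c1ncc(-c2ccccc2F)o1`, in an assay (Rattus norvegicus) for inhibition of Fatty-acid amide hydrolase 1 (Homo sapiens) (on this read-out higher numbers stand for weaker inhibition and lower numbers for stronger inhibition), gives 110 nM
- compound 2, `COC(=O)c1cccc(-c2cnc(C(=O)CCCCCCc3ccccc3)o2)c1`, in this assay gives 12 nM

Compound 2 carries the lowest of the two numbers recorded in this assay. Its nearest neighbour is compound 1, whose number is higher by a margin that lies beyond the scatter of repeated measurements, so on the values shown compound 2 is the stronger inhibitor of the two. Among the measured compounds shown here, no pair of measured compounds differs in only one place, so no single-point step can be read off from the data as they stand.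

Compound 3, `O=C(CCCCCCc1ccccc1)c1ncc(-c2cccc(O)c2)o1`, is related to compound 2 by a single change: hydroxy in place of methoxycarbonyl on an aromatic carbon, a hydroxy in place of methoxycarbonyl on an aromatic carbon, meta to a large group. For the measured compounds named here, the data give no measured step of this kind, so the size of the step in this assay is uncertain. A modest rise in the number, at the edge of the scatter or a little beyond it, is expected, so that the estimated step is a 2.5-fold higher number from compound 2 to compound 3 (0.40 log units; beyond the scatter). For compound 3 the value in this assay is estimated at 30 nM, within a range from 8 nM to 120 nM.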

Compound 3, inhibition constant: 50 nM
Estimate against measurement, compound 3: 1.7-fold (0.22 log units) below; measured number inside the range.
By their numbers in this assay, from the lowest: compound 2; then compound 3; then compound 1.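

In this assay, among the compounds shown here, hydroxy in place of methoxycarbonyl on an aromatic carbon, meta to a large group, gives a 4.2-fold higher number from compound 2 to compound 3 (0.62 log units; beyond the scatter) and so supplies the one measured step at this place; it is modest, yet it shows that the choice of group here changes the number beyond the scatter. Set against the other aryl group, 3-hydroxyphenyl in place of 2-fluorophenyl gives a 2.2-fold lower number from compound 1 to compound 3 (0.34 log units; beyond the scatter) and is also modest, which places the three compounds in the order compound 2, compound 3, compound 1 from the lowest number, although this second step changes both the group and its place on the ring, so the two cannot be told apart. No measurement among those shown accounts for either step.

The compounds shown leave open how a carboxylic acid or an amine at this same place would compare with methoxycarbonyl and hydroxy. They also leave open whether methoxycarbonyl or hydroxy on another carbon of the ring, or a fluorine at this place, would give a similar number with the same seven-carbon-free question of the chain left untouched, since a longer chain on the carbonyl is not among them.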